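The source may hold more compounds than are shown below. What is called first, only, known or untested is meant among the compounds shown, and "the series" means these compounds.

In an ADME assay on CCRF-HSB-2 cells (Homo sapiens) for cytotoxicity, with a stated time of 7 days (a higher number here means that more compound is tolerated, a lower number that less compound is tolerated), compound 1, `C=CCOc1nc(N)nc2c1ncn2/C=C1/CC1(CO)CO`, gives > 20000 nM, which is a limit of the assay and not a number. Compound 2, `CCOc1nc(N)nc2c1ncn2/C=C1/CC1(CO)CO`, gives > 20000 nM, which is also a limit. Compound 2 therefore has no exact value, and the only other compound shown offers none either: the two share (the limit of > 20000 nM in this assay, at which 2 of the 2 values shown sit).

Compound 3, `CN(C)c1nc(N)nc2c1ncn2/C=C1/CC1(CO)CO`, has not yet been measured. Its structural change is dimethylamino in place of ethoxy on an aromatic carbon, with dimethylamino in place of ethoxy on an aromatic carbon, while the rest of the structure stays the same.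

For the measured compounds named here, only one measured step can serve as a guide. This is a step that the two limits leave unreadable from compound 1 to compound 2, which changes the chain on the oxygen rather than replacing the whole group, and its size cannot be read. Going by the values given here, with no sized step to draw on, no step beyond the scatter is expected in this assay, and no direction can be given. The estimated step is a step that the limit leaves unreadable from compound 2 to compound 3. For compound 3 the expected value is 25000 nM, with an estimated range from 9000 nM to 60000 nM.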

Compound 3, half-maximal cytotoxic concentration: > 20000 nM
Compound 3: no number, only a limit; the forecaster's own chance of this, stated with the estimate: 80%; the middle value is on the limit's open side.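

The steps linking compound 3 to compound 1 and to compound 2 cannot be read, since all three compounds give a limit of the assay and not a number: the limit of > 20000 nM in this assay, at which 3 of the 3 values shown sit.

The compounds shown leave open at what concentration any of the three becomes cytotoxic in this assay, and whether allyloxy, ethoxy and dimethylamino differ there at all.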